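Urea series: removing one trifluoromethyl from compound 2

A few compounds are considered here, and "the series" means these few. Any claim that something is new, unique, unknown or untested is made for them only; others in the source may bear on it.

Measured so far:
compound 1 `O=C(Nc1cccc(-n2cc(-c3ccncc3)c(-c3cc(O)cc(Cl)c3)n2)c1)Nc1ccc(Cl)c(C(F)(F)F)c1`: -24.9%
compound 2 `COc1cc(Cl)cc(-c2nn(-c3cccc(NC(=O)Nc4cc(C(F)(F)F)cc(C(F)(F)F)c4)c3)cc2-c2ccncc2)c1`: -19.2%

In a functional assay on Malme-3M cells (Homo sapiens) for inhibition, read by sulforhodamine B assay, with a stated time of 48 h, tested at 10 uM (a lower number here means a stronger effect, a higher number a weaker effect of the compound at the concentration tested), compound 1 gives -24.9%, and compound 2 gives -19.2%. Compound 2 holds the higher of the two numbers, but compound 1 lies within the scatter of it, so no order between the two is claimed.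

Compound 3 `COc1cc(Cl)cc(-c2nn(-c3cccc(NC(=O)Nc4cccc(C(F)(F)F)c4)c3)cc2-c2ccncc2)c1` differs from compound 2 by one change: hydrogen in place of trifluoromethyl on an aromatic carbon. Among the measured compounds shown here, no step between measured compounds is known, so nothing here tells how this change moves the read-out. The step of a number 4.2 percentage points higher from compound 2 to compound 3 (within the scatter) is expected to stay within the scatter, with no clear direction. Compound 3 is expected near -15%, in the range -40% to 10%.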

Compound 3, a percentage reported as activity, at one concentration (the size of the read-out at that concentration, not a potency): -16.6%
The estimate for compound 3 lay 1.6 percentage points above the measured number; measured number inside the range.
By their numbers in this assay, from the lowest: compounds 1, 2 and 3 (each within the scatter of the next).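

In this assay, hydrogen in place of trifluoromethyl on an aromatic carbon gives the series its first readable step, a number 2.6 percentage points higher from compound 2 to compound 3 (within the scatter). At this position, meta to a trifluoromethyl group, the read-out therefore does not separate hydrogen from trifluoromethyl, even with 4 heavy atoms gone. Nothing at hand offers a reason for this result.

On these data alone, whether an amine, a nitrile or a carboxylic acid at this position would move the read-out remains open. So does the effect of replacing the remaining trifluoromethyl of compound 3 with hydrogen.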